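Working notes: from compound 3 to compound 4

The compounds below may be only part of what the source reports. "The series", "measured", "known", "first", "only" and "open" are said of these compounds alone.

Measured so far in a functional assay on PC-3 cells (Homo sapiens) for cytotoxicity, read by colorimetric assay and MTT assay (on this read-out higher numbers stand for weaker inhibition and lower numbers for stronger inhibition), on the series:
- compound 1 `CCOC(=O)Cn1c(=O)c(-c2ccc(OC)cc2)cc2c(OC)cc(OC)cc21` gives 10000 nM
- compound 2 `CCN(CC)C(=O)Cn1c(=O)c(-c2ccc(OC)cc2)cc2c(OC)cc(OC)cc21` gives 10000 nM
- compound 3 `COc1ccc(-c2cc3c(OC)cc(OC)cc3n(CCCC#N)c2=O)cc1` gives 10000 nM

Compounds 1 and 2 sit level with compound 3 at 10000 nM on these numbers. The next structure is compound 4 `COc1ccc(-c2cc3c(OC)cc(OC)cc3n(CC(=O)OCc3ccccc3)c2=O)cc1`, with benzyloxycarbonyl in place of 2-cyanoethyl on a saturated chain carbon bound to an aromatic nitrogen.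

Going by the values given here, three measured steps bear on this place: no change at the digits printed from compound 1 to compound 2 (within the scatter) with diethylamino in place of ethoxy on a carbonyl carbon, no change at the digits printed from compound 1 to compound 3 (within the scatter) with 2-cyanoethyl in place of ethoxycarbonyl, and no change at the digits printed from compound 2 to compound 3 (within the scatter) with 2-cyanoethyl in place of diethylcarbamoyl. As far as these compounds go, none of these steps brings in a six-membered aromatic ring of carbon only, so that part of the change remains untested. With all three steps flat, no shift beyond the scatter is expected, and the expected outcome in this assay is no change at the digits printed from compound 3 to compound 4 (within the scatter) on this estimate. For compound 4 the estimated value is 10000 nM with an expected range from 4000 nM to 15000 nM in this read-out.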

Compound 4, half-maximal inhibitory concentration: 10000 nM
For compound 4 middle estimate and measured number coincide at the digits printed; low and high end bracket the measured number.
By their numbers in this assay, from the lowest: compounds 1, 2, 3 and 4 (each within the scatter of the next).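

In this assay, benzyloxycarbonyl on a saturated chain carbon bound to an aromatic nitrogen brings in a six-membered aromatic ring of carbon only, unlike the earlier groups, and the reading stays flat (no change at the digits printed from compound 3 to compound 4 (within the scatter)). The two ester and amide comparisons agree: benzyloxy in place of diethylamino on a carbonyl carbon (no change at the digits printed from compound 2 to compound 4 (within the scatter)) and phenyl in place of methyl on a saturated chain carbon bound to an oxygen next to a carbonyl group (no change at the digits printed from compound 1 to compound 4 (within the scatter)) also leave the digits unmoved. No measured evidence accompanies these readings to account for them.

With all four compounds level, the series does not show whether any group at this place can shift the number. As far as these compounds go, whether an amine or a carboxylic acid on the chain would read differently in this assay stays open.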